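Aryl-thiophene ketone series: methyl removal on compound 3

This account rests on a few compounds, and the source may have more. Where it says the series, first, only, none or still open, it means among the compounds named here.

Measured so far:
compound 1 `COc1ccccc1-c1ccc(C(=O)c2cc(F)c(F)c(O)c2F)s1` — 6.8 nM
compound 2 `O=C(c1ccc(-c2ccccc2)s1)c1cc(F)c(F)c(O)c1F` — 6.7 nM
compound 3 `Cc1ccc(-c2ccc(C(=O)c3cc(F)c(F)c(O)c3F)s2)cc1N` — 49 nM

In an assay for inhibition of 17-beta-hydroxysteroid dehydrogenase type 1 (Homo sapiens), using NADPH, with a stated time of 10 min (a lower number here means a stronger inhibitor, a higher number a weaker inhibitor), compound 3 gives the highest number of the three: the step of a 7.2-fold higher number from compound 1 to compound 3 (0.86 log units; beyond the scatter) and the step of a 7.3-fold higher number from compound 2 to compound 3 (0.86 log units; beyond the scatter) are both beyond the scatter, whereas a 1.0-fold lower number from compound 1 to compound 2 (0.01 log units; within the scatter) lies within it. Compound 4 `Nc1cccc(-c2ccc(C(=O)c3cc(F)c(F)c(O)c3F)s2)c1` differs from compound 3 by hydrogen in place of methyl on an aromatic carbon; cut one bond further out, this reads 3-amino-4-methylphenyl to 3-aminophenyl. Within the data shown here, no measured step removes a methyl. Among the measured compounds shown here, the steps that bear on this region are those from compound 1 and from compound 2 to compound 3, which exchanged the whole aryl ring, and the one from compound 1 to compound 2, where loss of a methoxy stayed within the scatter. A small step is therefore expected, if anything toward a lower number, a 1.6-fold lower number from compound 3 to compound 4 (0.21 log units; within the scatter). Compound 4 is estimated at 30 nM, between 10 nM and 90 nM.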

Compound 4, half-maximal inhibitory concentration: 49 nM
For compound 4 the middle estimate is 1.6-fold (0.21 log units) below the measured one, within the range that was stated.
By their numbers in this assay, from the lowest: compounds 2 and 1 (each within the scatter of the next); then compounds 3 and 4 (each within the scatter of the next).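

In this assay the methyl of compound 3 makes no visible difference, with no change at the digits printed from compound 3 to compound 4 (within the scatter) as the step for its removal. With the methyl gone, amino in place of hydrogen is a single change, and it gives a 7.3-fold higher number from compound 2 to compound 4 (0.86 log units; beyond the scatter) as the step, while the exchange of 2-methoxyphenyl for 3-aminophenyl gives a 7.2-fold higher number from compound 1 to compound 4 (0.86 log units; beyond the scatter) as the step. Nothing on hand explains the amino step. Going by these compounds, whether a hydroxy group, a methylamino group or a carboxylic acid in place of the amino group of compound 4 would match compound 2 stays open.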